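The source may hold more compounds than are shown below. What is called first, only, known or untested is meant among the compounds shown, and "the series" means these compounds.

Working notes on the series. In a functional assay on DU-145 cells (Homo sapiens) for cytotoxicity, read by CCK-8 assay and cell counting, with a stated time of 2 days (on this read-out lower numbers stand for stronger inhibition and higher numbers for weaker inhibition), compound 1 `Oc1ccc(-c2cc(-c3ccc(Cl)cc3)nc(-c3ccsc3)c2)cc1` gives 6940 nM, compound 2 `Oc1cccc(-c2cc(-c3ccc(Cl)cc3)nc(-c3ccsc3)c2)c1` gives 11600 nM and compound 3 `Oc1cccc(-c2cc(-c3ccccc3)nc(-c3ccc(Cl)cc3)c2)c1` gives 11200 nM; the number for compound 2 does not part from those of compound 1 or compound 3 beyond the scatter, as a 1.7-fold higher number from compound 1 to compound 2 (0.22 log units; within the scatter) and a 1.0-fold lower number from compound 2 to compound 3 (0.02 log units; within the scatter) show. Compound 4 `Oc1cccc(-c2cc(-c3ccsc3)nc(-c3ccccc3Cl)c2)c1` differs from compound 2 in one place: 2-chlorophenyl in place of 4-chlorophenyl on an aromatic carbon. Among the compounds with values here, no measured step moves the chlorine on that ring, so the two steps seen, both within the scatter, give only a weak guide and suggest a flat series. Compound 4 is therefore expected to stay close to compound 2, with a 1.1-fold lower number from compound 2 to compound 4 (0.02 log units; within the scatter), estimated at 11000 nM in this assay, within 4000 nM to 30000 nM.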

Compound 4, half-maximal inhibitory concentration: 1970 nM
Compound 4: the middle estimate sits 5.6-fold (0.75 log units) above what was measured; the whole stated range lies above it.
By their numbers in this assay, from the lowest: compound 4; then compounds 1, 3 and 2 (each within the scatter of the next).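

In this assay, 2-chlorophenyl in place of 4-chlorophenyl, on the aromatic carbon next to the ring nitrogen, gives a 5.9-fold lower number from compound 2 to compound 4 (0.77 log units; beyond the scatter), the only step shown that lies beyond the scatter. The two groups have the same atoms, so the series is not flat at this position: where the chlorine sits on this ring changes the number, whereas the two earlier steps did not. No measurement shown gives a reason for this step. Open, going by these compounds, is whether a methyl or methoxy group in place of that chlorine gives a similar step, and whether the step holds with 4-hydroxyphenyl in place of 3-hydroxyphenyl.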